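The compounds below may be only part of what the source reports. "The series", "measured", "known", "first", "only" and "open" are said of these compounds alone.

Three compounds sharing one core were tested in a toxicity assay on the whole organism with Rattus norvegicus as the target, at a dose of 400 mg/kg by the oral route; on this read-out higher numbers stand for a stronger effect at the one dose given and lower numbers for a weaker effect. Compound 1 `Clc1ccc(OCC2=NCCO2)cc1` gives 90% in this assay. Compound 2 `Brc1ccccc1OCC1=NCCO1` gives 100%, and compound 3 `Clc1ccccc1OCC1=NCCO1` gives 60%. Compound 1 and compound 3 are built from the same atoms joined differently; the difference between the two cores is not broken down here, and their two values show compound 1 higher than compound 3 by a margin beyond the usual scatter. The values of compound 1 and compound 2 lie within the scatter of each other, so no order between them is claimed.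

One step between measured compounds is counted: bromo in place of chloro on an aromatic carbon. It gave a number 40 percentage points higher from compound 3 to compound 2 (beyond the scatter).

Compound 4 `Brc1ccc(OCC2=NCCO2)cc1` has not yet been measured in this assay. It differs from compound 1 by bromo in place of chloro on an aromatic carbon. For the measured compounds named here, this is the same kind of change as the one from compound 3 to compound 2, though not the same: in compound 4 the bromo sits para to a group of 7 heavy atoms, whereas in compound 2 it sits ortho to a group of 7 heavy atoms. The expected step is a number 10 percentage points higher from compound 1 to compound 4 (within the scatter), set beside a number 40 percentage points higher from compound 3 to compound 2 (beyond the scatter); the expectation rests on that single earlier step and on compound 1 already giving 90%, which leaves little room upward on a percentage read-out. Compound 4 is therefore estimated at 100%, with a range from 85% to 100%.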

Compound 4, a percentage reported as activity, at one dose (the size of the read-out at that dose, not a potency): 100%
Beside the measured number, compound 4's estimate shows no gap at the digits printed; the measured number falls inside the stated range.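

In this assay, bromo in place of chloro on an aromatic carbon gave a number 10 percentage points higher from compound 1 to compound 4 (within the scatter), so on the core of compound 1 this change shows no effect that can be told from the scatter. Set beside the earlier step, the change does not carry over at the same size from one core to the other: the same change on two cores in this assay, a number 40 percentage points higher (beyond the scatter) from compound 3 to compound 2 and a number 10 percentage points higher (within the scatter) from compound 1 to compound 4, 30 percentage points apart, beyond the scatter of two such steps. What this does not show is the reason, since two steps cannot separate the place of the bromo, para to a group of 7 heavy atoms in compound 4, from the different starting values, with compound 1 at 90% and compound 3 at 60%.

The compounds shown carry only chloro or bromo on the aromatic ring, so it remains open whether fluoro, iodo, methyl or methoxy there would follow the larger step, the smaller one or neither. Also open, from the compounds shown here alone, is how the read-out would respond to a change elsewhere, such as an amine on the ring or a longer chain joining the aromatic ring to the other ring.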